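The source may report more compounds than this note shows. Statements on the series, on what has been measured and on what is new or still open speak of the compounds shown alone.

In an ADME assay on L6 cells (Rattus norvegicus) for cytotoxicity (a higher number here means a weaker inhibitor, a lower number a stronger inhibitor), the three measured compounds stand as follows:

Compound 1, `O=C(CCN1CCCC1)OC1CC2(N3CCCC3)CC(c3ccccc3)C1C(c1ccccc1)C2`, gives 21900 nM.
Compound 2, `O=C(CCN1CCCC1)OC1CC2(N3CCCCC3)CC(c3ccccc3)C1C(c1ccccc1)C2`, gives 12500 nM.
Compound 3, `O=C(CCN1CCCCC1)OC1CC2(N3CCCC3)CC(c3ccccc3)C1C(c1ccccc1)C2`, gives 17800 nM.

Compound 4, `O=C(CCN1CCCCC1)OC1CC2(N3CCCCC3)CC(c3ccccc3)C1C(c1ccccc1)C2`, has not yet been measured. Compound 1 and compound 3 share most of their structure; the one difference between them is piperidin-1-yl in place of pyrrolidin-1-yl on a saturated chain carbon, two bonds along the chain from a carbonyl carbon, and in this assay that difference gave a 1.2-fold lower number from compound 1 to compound 3 (0.09 log units; within the scatter).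

The change from compound 1 to compound 2 is piperidin-1-yl in place of pyrrolidin-1-yl on a saturated ring carbon. In this assay it made a 1.8-fold lower number from compound 1 to compound 2 (0.24 log units; within the scatter), a step that sits within the usual scatter of repeated measurements.

The change from compound 3 to compound 4 is piperidin-1-yl in place of pyrrolidin-1-yl on a saturated ring carbon. Within the data shown here, it is the same kind of change as the one from compound 1 to compound 2, at the same position of the shared core, but the surroundings are not identical word for word: in compound 1 the ring atom two ring bonds away bears a ((2-(pyrrolidin-1-yl)ethyl)carbonyl)oxy group, whereas in compound 3 that ring atom bears a ((2-(piperidin-1-yl)ethyl)carbonyl)oxy group. Among the measured compounds shown here, with only one earlier example of this kind of change, the expectation rests on a single step.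

Because the earlier step of this kind gave a 1.8-fold lower number from compound 1 to compound 2 (0.24 log units; within the scatter), the expected step is a 1.7-fold lower number from compound 3 to compound 4 (0.23 log units; within the scatter). Compound 4 is therefore estimated at 10500 nM in this assay, with a plausible range from 5000 nM to 22000 nM.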

Compound 4, half-maximal inhibitory concentration: 54600 nM
Estimate against measurement, compound 4: 5.2-fold (0.72 log units) below, outside the stated range (above it).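

With piperidin-1-yl already in the other place, the swap on the saturated ring carbon gives a 3.1-fold higher number from compound 3 to compound 4 (0.49 log units; beyond the scatter) and the swap on the saturated chain carbon gives a 4.4-fold higher number from compound 2 to compound 4 (0.64 log units; beyond the scatter) in this assay. The ring-carbon swap therefore does not carry over from one core to the other, as a step within the scatter on one core becomes a step beyond it on the other: the same change on two cores in this assay, a 1.8-fold lower number (0.24 log units; within the scatter) from compound 1 to compound 2 and a 3.1-fold higher number (0.49 log units; beyond the scatter) from compound 3 to compound 4, 5.4-fold (0.73 log units) apart, beyond the scatter of two such steps. The chain-carbon swap fails to carry over in the same way, which shows that in these four compounds the effect of a swap in one place depends on the group in the other place, but it does not show why, or whether this holds on any other core: the same change on two cores in this assay, a 1.2-fold lower number (0.09 log units; within the scatter) from compound 1 to compound 3 and a 4.4-fold higher number (0.64 log units; beyond the scatter) from compound 2 to compound 4, 5.4-fold (0.73 log units) apart, beyond the scatter of two such steps.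

The compounds shown leave open whether the higher number needs piperidin-1-yl in both places or would also appear with other amines there, such as morpholin-4-yl or azepan-1-yl. They also leave open what a longer chain between the carbonyl and the amine would do to this dependence.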